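Trifluoromethoxy at the styryl ring of a chromone

The source may hold more compounds than are shown below. What is called first, only, known or untested is meant among the compounds shown, and "the series" means these compounds.

Measured so far:
compound 1, `COc1cc(OC)c2c(=O)cc(/C=C/c3ccccc3)oc2c1`, 21500 nM
compound 2, `COc1ccc2c(=O)cc(/C=C/c3ccc(OC(F)(F)F)cc3)oc2c1OC`, limit > 40000 nM

In a functional assay on A549 cells (Homo sapiens) for antiproliferative activity, read by MTT assay, with a stated time of 12 h (a lower number here means a stronger inhibitor, a higher number a weaker inhibitor), compound 1 gives 21500 nM. Going by the values given here, that is the only number in this set, since the other value is a limit: compound 2 reaches only > 40000 nM in this assay, which is a limit of the assay rather than a number. Among the compounds with values here, compound 2 therefore sits at the limit of > 40000 nM in this assay, at which 1 of the 2 values shown sits, so compound 1 stands alone as the one compound with a measured value.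

Compound 3, `COc1cc(OC)c2c(=O)cc(/C=C/c3ccc(OC(F)(F)F)cc3)oc2c1`, differs from compound 1 by trifluoromethoxy in place of hydrogen on an aromatic carbon. Within the data shown here, no step between two measured compounds covers this change; only the limit of compound 2 offers any bearing. Compound 3 is therefore expected to be weak, with a step of a 1.6-fold higher number from compound 1 to compound 3 (0.21 log units; within the scatter) going toward weaker inhibition, though it may not exceed the scatter. The estimate for compound 3 is 35000 nM, in a range of 15000 nM to 90000 nM.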

Compound 3, half-maximal inhibitory concentration: 24200 nM
Compound 3: middle estimate off by 1.4-fold (0.16 log units), on the high side; low and high end bracket the measured number.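

Trifluoromethoxy in place of hydrogen on this aromatic carbon, para to a large group, gives the first step that can be read in this assay: a 1.1-fold higher number from compound 1 to compound 3 (0.05 log units; within the scatter). On the core of compound 1, the entry of this group thus leaves compound 3 indistinguishable from its parent in this read-out. Compound 2 also carries trifluoromethoxy, but its value is a limit and not a number, and its methoxy groups sit differently on the core, so it cannot be read against this step: the limit of > 40000 nM in this assay, at which 1 of the 3 values shown sits.

As far as these compounds go, whether an amine, a carboxylic acid or a longer chain at this same place would also leave the read-out within the scatter remains open. Also open is what the methoxy groups on the core contribute, since no pair shown differs there alone.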